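Lipoxygenase inhibitor series: ring size at the benzylic carbon

The source may report more compounds than this note shows. Statements on the series, on what has been measured and on what is new or still open speak of the compounds shown alone.

Measured compounds, potency in a functional assay for inhibition of Polyunsaturated fatty acid 5-lipoxygenase (Homo sapiens); a lower number here means a stronger inhibitor, a higher number a weaker inhibitor:
- compound 1, `CCCCC(O/N=C/C(=O)O)c1ccc(OCc2ccc3ccccc3n2)cc1`: 52 nM
- compound 2, `CCCCC(CCCC)C(O/N=C/C(=O)O)c1ccc(OCc2ccc3ccccc3n2)cc1`: 10 nM
- compound 3, `O=C(O)/C=N/OC(c1ccc(OCc2ccc3ccccc3n2)cc1)C1CCCCCC1`: 18 nM

Compound 3 stands second lowest of the three numbers. Its nearest neighbour is compound 2, and the step of a 1.8-fold higher number from compound 2 to compound 3 (0.26 log units; within the scatter) lies within the scatter, so the two cannot be ordered. The step of a 2.9-fold lower number from compound 1 to compound 3 (0.46 log units; beyond the scatter) is beyond the scatter, as is a 5.2-fold lower number from compound 1 to compound 2 (0.72 log units; beyond the scatter).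

Compound 4, `O=C(O)/C=N/OC(CC1CCCCC1)c1ccc(OCc2ccc3ccccc3n2)cc1`, is the next member. The change from compound 3 is cyclohexylmethyl in place of cycloheptyl on a saturated chain carbon bound to an aromatic carbon and an oxygen. The two measured steps that bear on it both describe what happens when the butyl of compound 1 is replaced by a larger saturated group: modest gains in each case, and the two enlarged variants, compound 2 and compound 3, sit within the scatter of one another. Compound 4 keeps the same atom count and the same saturated, uncharged character at the same place, only rearranged. Going by the values given here, no measured step distinguishes a ring attached directly from one set off by a single chain carbon, so the expectation is that compound 4 stays near compound 3, the expected step of no change at the digits printed from compound 3 to compound 4 (within the scatter) being within the scatter. Compound 4 is therefore estimated at 18 nM, with a range from 8 nM to 40 nM in this assay.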

Compound 4, half-maximal inhibitory concentration: 27 nM
The estimate for compound 4 lay 1.5-fold (0.18 log units) below the measured number; the measured number falls inside the stated range.
By their numbers in this assay, from the lowest: compounds 2, 3, 4 and 1 (each within the scatter of the next, the first and the last beyond it).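

Within this assay the rearrangement of cycloheptyl to cyclohexylmethyl on the saturated chain carbon bound to an aromatic carbon and an oxygen gives a 1.5-fold higher number from compound 3 to compound 4 (0.18 log units; within the scatter) and so cannot be ordered: at this position, a seven-membered ring attached directly and a six-membered ring set off by one chain carbon are not told apart. The step of a 2.7-fold higher number from compound 2 to compound 4 (0.43 log units; beyond the scatter) nevertheless separates cyclohexylmethyl from 1-butylpentyl, a separation that cycloheptyl did not show. The step of a 1.9-fold lower number from compound 1 to compound 4 (0.28 log units; within the scatter) also leaves cyclohexylmethyl unresolved from butyl, whereas cycloheptyl was resolved from it, so the gain over butyl is not secured for both groups of seven carbons, even though those two groups lie within the scatter of each other.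

Still open, on these data alone, is whether a phenyl ring, or a piperidine ring with its nitrogen, would give numbers of this order at the same carbon, and whether a longer link such as cyclohexylethyl would move the number beyond the scatter. No measurement at hand accounts for any of these steps.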